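This account rests on a few compounds, and the source may have more. Where it says the series, first, only, none or still open, it means among the compounds named here.

Compound 1 `CS(=O)(=O)c1ccc(Cc2nnc3n2N=C(c2ccccc2)CS3)cc1` gives 42% in a functional assay on RAW264.7 cells (Mus musculus) for cytotoxicity, read by MTT assay, with a stated time of 48 h, tested at 12.5 uM; on this read-out higher numbers stand for a stronger effect at the one concentration tested and lower numbers for a weaker effect. Compound 2 `CS(=O)(=O)c1ccc(Cc2nnc3n2N=C(c2cc(Cl)sc2S(N)(=O)=O)CS3)cc1` gives 22.8% in this assay, and the change a number 19.2 percentage points lower from compound 1 to compound 2 (beyond the scatter) is beyond the scatter, with 5-chloro-2-sulfamoylthiophen-3-yl in place of phenyl on a carbon with a double bond to nitrogen. Compound 3 `CS(=O)(=O)c1ccc(Cc2nnc3n2N=C(c2cc(Cl)sc2Cl)CS3)cc1` was reported as "not active" (no number reported) in this assay, with no single number, so it stands below both compound 1 and compound 2 without a measured value. Compound 4 `Cc1ccc(C2=Nn3c(Cc4ccc(S(C)(=O)=O)cc4)nnc3SC2)cc1` differs from compound 3 by 4-methylphenyl in place of 2,5-dichlorothiophen-3-yl on a carbon with a double bond to nitrogen. The step from compound 1 to compound 2 bears on this change in reverse, since compound 4 returns to a six-membered carbon ring as in compound 1. Compound 4 is therefore expected to rise from the inactive compound 3 toward compound 1, at an estimated 38%, ranging from 20% to 55%.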

Compound 4, a percentage reported as activity, at one concentration (the size of the read-out at that concentration, not a potency): "not active" (no number reported)
No number was reported for compound 4; the estimate stays without a comparison.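

Compound 3 and compound 4 were both reported as not active, with no number for either, so no step can be read between them. The compounds shown leave open whether 2,5-dichlorothiophen-3-yl and 4-methylphenyl differ in effect at all. No supporting evidence bears on this result.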